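The compounds below may be only part of what the source reports. "The series", "measured", "known", "first", "only" and "open" are said of these compounds alone.

Measured so far in a functional assay on the whole organism (Ear) for inhibition, with Mus musculus as the target, at a dose of 40 mg/kg by the oral route; on this read-out higher numbers stand for more inhibition at the one dose given (going by the name of the read-out) and lower numbers for less inhibition:

Compound 1 `CC(=O)Oc1ccc(-c2ccc(F)cc2F)cc1C(=O)O` — compound 1 gives 13.7%
Compound 2 `O=C(Oc1ccc(-c2ccc(F)cc2F)cc1C(=O)O)c1ccccc1` — compound 2 gives 16.1%
Compound 3 `CNC(=O)c1cc(-c2ccc(F)cc2F)ccc1OC(C)=O` — compound 3 gives 48.8%

Compound 3 stands highest of the three numbers in this assay: its nearest neighbour is compound 2, and the step of a number 35.1 percentage points higher from compound 1 to compound 3 (beyond the scatter) is a large one, beyond the scatter, arising from methylamino in place of hydroxy on a carbonyl carbon. Compounds 1 and 2 lie within the scatter of each other.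

Compound 4 `CNC(=O)c1cc(-c2ccc(F)cc2F)ccc1OC(=O)c1ccccc1` has not been measured. It differs from compound 3 in one place: phenyl in place of methyl on a carbonyl carbon — acetyl to benzoyl, acetoxy to benzoyloxy. The same change has been measured once in this series, between the two compounds carrying hydroxy on the other carbonyl carbon, where a number 2.4 percentage points higher from compound 1 to compound 2 (within the scatter) stayed within the scatter. For the measured compounds named here, no other measured pair bears on it. The expectation for compound 4 is therefore a step of a number 1.2 percentage points higher from compound 3 to compound 4 (within the scatter) in this assay, no change beyond the scatter. Compound 4 is estimated at 50%, with a range of 34% to 66%.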

Compound 4, a percentage reported as inhibition, in the whole organism at one dose (the size of the read-out at that dose, not a potency): 68.9%
Compound 4: the middle estimate sits 18.9 percentage points below what was measured; the measured number lies above the stated range.
By their numbers in this assay, from the lowest: compounds 1 and 2 (each within the scatter of the next); then compound 3; then compound 4.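

In this assay, phenyl in place of methyl on a carbonyl carbon now counts where methylamino sits on the other carbonyl carbon, giving a number 20.1 percentage points higher from compound 3 to compound 4 (beyond the scatter). The size of this step therefore depends on the group on the other carbonyl carbon, so the two changes do not simply add on the shared core: the same change on two cores in this assay, a number 2.4 percentage points higher (within the scatter) from compound 1 to compound 2 and a number 20.1 percentage points higher (beyond the scatter) from compound 3 to compound 4, 17.7 percentage points apart, beyond the scatter of two such steps. Read the other way, methylamino in place of hydroxy gains more with benzoyloxy, at a number 52.8 percentage points higher from compound 2 to compound 4 (beyond the scatter), than with acetoxy: the same change on two cores in this assay, a number 35.1 percentage points higher (beyond the scatter) from compound 1 to compound 3 and a number 52.8 percentage points higher (beyond the scatter) from compound 2 to compound 4, 17.7 percentage points apart, beyond the scatter of two such steps.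

The compounds shown leave open whether this gain requires the aromatic ring or follows from carbon count alone, a question that a cyclohexyl or a longer alkyl chain on this carbonyl carbon would address. Also open, from the compounds shown here alone, is whether an amino or dimethylamino group in place of methylamino keeps the benzoyloxy gain.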